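The source may hold more compounds than are shown below. What is called first, only, known or untested is meant among the compounds shown, and "the series" means these compounds.

Measured compounds:
- compound 1, `O=C(O)CCn1c(=O)oc2cc(OCc3ccccn3)c(Cl)cc21`: 11 nm/s
- compound 2, `C[C@@H](Oc1cc2oc(=O)n(CCC(=O)O)c2cc1Cl)c1ccc(Cl)cn1`: 60 nm/s

Within the data shown here, in a physicochemical assay for permeability, using PAMPA (a higher number here means that the compound crosses the layer faster, a lower number that the compound crosses the layer more slowly), compound 1 stands lowest of the two numbers measured so far. Its nearest neighbour, compound 2, gives a higher number, a gap that lies beyond the usual scatter of this assay. There is no single-point comparison between the two measured compounds, so their values say only where each one sits.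

Compound 3, `C[C@@H](Oc1cc2oc(=O)n(CCC(=O)O)c2cc1Cl)c1cccnn1`, has not yet been measured. It differs from compound 1 in one place:

a group of 8 heavy atoms (6 carbon, 2 nitrogen; one six-membered aromatic ring with 2 hetero atoms) in place of a group of 7 heavy atoms (6 carbon, 1 nitrogen; one six-membered aromatic ring with 1 hetero atom), on an oxygen on an aromatic ring

Compound 1 thus gives up the (pyridin-2-yl)methyl group on the aromatic oxygen and gains a somewhat larger group with a second ring nitrogen and a defined stereocentre in its place. Among the measured compounds shown here, with no measured step of this kind available, the size of the change for compound 3 in this assay is expected to be small, most likely within the scatter, and if anything slightly upward, as a 1.4-fold higher number from compound 1 to compound 3 (0.13 log units; within the scatter). For compound 3 the estimated value in this assay is 15 nm/s, with a likely range from 5 nm/s to 45 nm/s.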

Compound 3, apparent permeability: < 3 nm/s
Compound 3: only a limit was reported (the forecaster's own chance of this, stated with the estimate: 5%); middle value at least 5.0-fold (0.69 log units) away from the limit.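

In this assay compound 3 gives < 3 nm/s, which is a limit of the assay and not a number, so both new steps give only a minimum size: the limit of < 3 nm/s in this assay, at which 1 of the 3 values shown sits.

Even so, the place on the oxygen on an aromatic ring is shown to matter, since putting the group with a six-membered aromatic ring with 2 hetero atoms and a defined stereocentre in place of (pyridin-2-yl)methyl gives an at least 3.6-fold lower number from compound 1 to compound 3 (0.56 log units; beyond the scatter). The cleaner comparison keeps the saturated chain carbon and changes only the ring on it, as pyridazin-3-yl in place of 5-chloropyridin-2-yl gives an at least 20-fold lower number from compound 2 to compound 3 (1.30 log units; beyond the scatter), a large step that shows this ring alone can move the read-out far.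

That ring change still alters the chlorine and the ring nitrogens together, and the step from the (pyridin-2-yl)methyl group alters the ring and the chain carbon together, so neither part can be weighed alone. As far as these compounds go, how a plain phenyl ring or an unsubstituted pyridin-2-yl ring on the same chain carbon would read remains open, and such a compound would help to separate these parts.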